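Swapping a Branched Side Chain on a Nitro Sulfonamide

The compounds below may be only part of what the source reports. "The series", "measured", "known", "first", "only" and "open" are said of these compounds alone.

Measured so far:
compound 1, `CCC(C)C(C(=O)Nc1ccc(C(C)=O)cc1)N(C(=O)c1ccccc1)S(=O)(=O)c1ccc(C)cc1`: 47.3%
compound 2, `CC(=O)c1ccc(NC(=O)C(CC(C)C)N(C(=O)c2ccccc2)S(=O)(=O)c2ccc([N+](=O)[O-])cc2)cc1`: 81.3%

In a functional assay for inhibition, read by spectrophotometry, with a stated time of 20 min, tested at 5 mg/mL (on this read-out lower numbers stand for a weaker effect and higher numbers for a stronger effect at the one concentration tested), compound 2 gives the higher of the two numbers, and compound 1 stands well below it, beyond the scatter. Compound 3, `CCC(C)C(C(=O)Nc1ccc(C(C)=O)cc1)N(C(=O)c1ccccc1)S(=O)(=O)c1ccc([N+](=O)[O-])cc1`, is not yet measured. It differs from compound 2 as sec-butyl in place of isobutyl on a saturated chain carbon bound to an amide-type nitrogen and a carbonyl carbon. No change between two measured compounds is available to gauge this swap, so the expected step from compound 2 to compound 3, a number 15.3 percentage points lower from compound 2 to compound 3 (beyond the scatter), is a modest decrease that may not exceed the scatter. Compound 3 is therefore estimated at 66%, within 42% to 86%.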

Compound 3, a percentage reported as inhibition, at one concentration (the size of the read-out at that concentration, not a potency): 53.2%
Compound 3: the middle estimate sits 12.8 percentage points above what was measured; the measured number falls inside the stated range.
By their numbers in this assay, from the lowest: compounds 1 and 3 (each within the scatter of the next); then compound 2.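

In this assay, sec-butyl in place of isobutyl gives a number 28.1 percentage points lower from compound 2 to compound 3 (beyond the scatter), so this saturated chain carbon distinguishes between two butyl groups made of the same atoms. With sec-butyl in place, nitro in place of methyl on an aromatic carbon gives a number 5.9 percentage points higher from compound 1 to compound 3 (within the scatter), so that swap has no readable effect alongside this chain. Nothing available explains either result. Still open, on these data alone, is whether nitro and methyl would also read alike alongside isobutyl, and how a longer chain or an amine would fare on the chain carbon.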